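Cytotoxicity notes on the step from compound 2 to compound 3

The compounds below may be only part of what the source reports. "The series", "measured", "known", "first", "only" and "open" are said of these compounds alone.

Compound 1 `CNc1nc(N)nc2c1ncn2/C=C1/CC1(CO)CO` and compound 2 `Nc1nc(N2CCCC2)c2ncn(/C=C3/CC3(CO)CO)c2n1` are the measured members of the series in an ADME assay on Akata cells (Homo sapiens) for cytotoxicity, with a stated time of 7 days; on this read-out higher numbers stand for lower toxicity in this test and lower numbers for higher toxicity in this test. For compound 1 the value > 24000 nM is a limit of the assay, not a number. For compound 2 the value > 24000 nM is likewise a limit of the assay and not a number. Going by the values given here, the only measured step, a step that the two limits leave unreadable from compound 1 to compound 2, therefore cannot be read, as the limit of > 24000 nM in this assay, at which 2 of the 2 values shown sit, records. Compound 3 `CCCOc1nc(N)nc2c1ncn2/C=C1/CC1(CO)CO` differs from compound 2 by propoxy in place of pyrrolidin-1-yl on an aromatic carbon. Among the compounds with values here, no measured step bears on this change, and both values known so far sit at the limit. In this assay compound 3 is therefore expected to remain at or beyond the same limit, an expected step that the limit leaves unreadable from compound 2 to compound 3 that would lie within the scatter. The estimate for compound 3 in this assay is 30000 nM, with a range from 12000 nM to 100000 nM, most likely reported again only as a limit.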

Compound 3, half-maximal cytotoxic concentration: > 20000 nM
Compound 3: no number, only a limit; the forecaster's own chance of this, stated with the estimate: 85%; the middle value lies beyond the limit too.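

In this assay compound 3 gives > 20000 nM, a limit and not a number. The steps to it from compound 1 and from compound 2 therefore cannot be read. The compounds shown leave open whether methylamino, pyrrolidin-1-yl and propoxy differ at all in this assay.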